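Bromo for Chloro, Repeated on a Second Core

The source may report more compounds than this note shows. Statements on the series, on what has been measured and on what is new or still open speak of the compounds shown alone.

Compound 1, with structure `O=C(Nc1ccc(Oc2ccnc3[nH]ccc23)cc1)c1cn(-c2ccc(Cl)cc2)c2ccccc2c1=O`, was tested in a functional assay on HepG2 cells (Homo sapiens) for inhibition, read by MTT assay, with a stated time of 72 h (on this read-out higher numbers stand for weaker inhibition and lower numbers for stronger inhibition), where compound 1 gives 250 nM. Compound 2, with structure `O=C(Nc1ccc(Oc2ccnc3[nH]ccc23)cc1)c1cn(-c2ccc(Br)cc2)c2ccccc2c1=O`, differs from compound 1 only by the change (bromo in place of chloro on an aromatic carbon), and in this assay compound 2 gives 220 nM. The step of a 1.1-fold lower number from compound 1 to compound 2 (0.06 log units; within the scatter) is therefore small, and the two numbers sit within the usual scatter of each other.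

Compound 3, with structure `Cn1ccc2c(Oc3ccc(NC(=O)c4cn(-c5ccc(Cl)cc5)c5ccccc5c4=O)cc3F)ccnc21`, carries a different core; the difference between the two cores is not broken down here. In this assay compound 3 gives 290 nM, a number that lies within the scatter of both compound 1 and compound 2.

Compound 4, with structure `Cn1ccc2c(Oc3ccc(NC(=O)c4cn(-c5ccc(Br)cc5)c5ccccc5c4=O)cc3F)ccnc21`, has not yet been measured. It is related to compound 3 by bromo in place of chloro on an aromatic carbon, the same change that separates compound 2 from compound 1, made at the same kind of place on the ring. Going by the values given here, the only evidence for what this change does comes from that single measured pair, where a 1.1-fold lower number from compound 1 to compound 2 (0.06 log units; within the scatter) stayed within the scatter. Among the compounds with values here, on that basis the step from compound 3 to compound 4 is expected to be about a 1.1-fold lower number from compound 3 to compound 4 (0.05 log units; within the scatter), because the one measured example, a 1.1-fold lower number from compound 1 to compound 2 (0.06 log units; within the scatter), was small. Compound 4 is accordingly estimated to give about 260 nM in this assay, with a plausible range from 130 nM to 520 nM.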

Compound 4, half-maximal inhibitory concentration: 1260 nM
Compound 4: the middle estimate sits 4.8-fold (0.69 log units) below what was measured; measured number above the stated range.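

In this assay, bromo in place of chloro on the core of compound 3 gives a 4.3-fold higher number from compound 3 to compound 4 (0.64 log units; beyond the scatter), which on this read-out means weaker inhibition, whereas the same change on the core of compound 1 left the number within the scatter. The size of this change's effect therefore did not carry over from one core to the other, since the two steps differ by more than their scatter allows: the same change on two cores in this assay, a 1.1-fold lower number (0.06 log units; within the scatter) from compound 1 to compound 2 and a 4.3-fold higher number (0.64 log units; beyond the scatter) from compound 3 to compound 4, 4.9-fold (0.69 log units) apart, beyond the scatter of two such steps This shows that a step measured on one core is not a safe guide to the same step on the other, but with a single pair on each core it does not show which of the differences between the cores matters, why the steps differ, or what the change would do on any further core.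

The compounds shown leave open whether the gap comes from the methyl group or the fluoro of the core of compound 3, which a core carrying only one of these could separate. They also leave open how other groups in place of chloro on the 4-chlorophenyl, such as iodo, methoxy or nitrile, would behave on each core.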